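This account rests on a few compounds, and the source may have more. Where it says the series, first, only, none or still open, it means among the compounds named here.

Working notes on the series.

Compound 1 `C=C1CC[C@@H]2[C@](C)(CO)[C@H](O)CC[C@@]2(C)[C@@H]1CC(Sc1ccc(C)cc1)C1=CCOC1=O` carries a sulfanyl-bearing side chain on the shared core and in a functional assay on PC-3 cells (Homo sapiens) for inhibition, read by MTT assay, with a stated time of 48 h (on this read-out lower numbers stand for stronger inhibition and higher numbers for weaker inhibition), compound 1 gives 29000 nM. Compound 2 `C=C1CC[C@@H]2[C@](C)(CO)[C@H](O)CC[C@@]2(C)[C@@H]1CC(Sc1ccc(F)cc1)C1=CCOC1=O` differs from compound 1 only by the change (fluoro in place of methyl on an aromatic carbon), and in this assay compound 2 gives 16000 nM. The step of a 1.8-fold lower number from compound 1 to compound 2 (0.26 log units; within the scatter) is small, so these two values are read as level with one another. Compound 3 `C=C1CC[C@@H]2[C@](C)(CO)[C@H](O)CC[C@@]2(C)[C@@H]1C/C=C1/C(=O)OC[C@H]1OC(=O)CCCSc1ccc(C)cc1` has a different arrangement of the lactone and side chain; the difference between the core of compound 1 and the core of compound 3 is not broken down here. In this assay compound 3 gives 16000 nM, level with compound 2 at the digits recorded.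

Compound 4 `C=C1CC[C@@H]2[C@](C)(CO)[C@H](O)CC[C@@]2(C)[C@@H]1C/C=C1/C(=O)OC[C@H]1OC(=O)CCCSc1ccc(F)cc1` is not yet measured. It differs from compound 3 by fluoro in place of methyl on an aromatic carbon, the same change as from compound 1 to compound 2, at the same place. Because the earlier step of a 1.8-fold lower number from compound 1 to compound 2 (0.26 log units; within the scatter) stayed within the scatter, a step of similar size is expected here, a 1.6-fold lower number from compound 3 to compound 4 (0.20 log units; within the scatter), with the direction uncertain. Compound 4 is therefore estimated at 10000 nM, in the range 5000 nM to 22000 nM, in this assay.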

Compound 4, half-maximal inhibitory concentration: 12000 nM
Compound 4: middle estimate off by 1.2-fold (0.08 log units), on the low side; the measured number falls inside the stated range.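

In this assay, replacing 4-methylphenyl with 4-fluorophenyl on the core of compound 3 gives a 1.3-fold lower number from compound 3 to compound 4 (0.12 log units; within the scatter), so compound 3 and compound 4 read as level. Set beside the same change on the core of compound 1, the two steps agree: the same change on two cores in this assay, a 1.8-fold lower number (0.26 log units; within the scatter) from compound 1 to compound 2 and a 1.3-fold lower number (0.12 log units; within the scatter) from compound 3 to compound 4, 1.4-fold (0.13 log units) apart, within the scatter of two such steps This shows that the change leaves the number level within the scatter on both cores, but with neither step beyond the scatter, it does not show that a real effect of the change carries from one core to the other, and two pairs in one assay set no rule for the wider series.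

The compounds shown leave open whether a chloro, a methoxy or an amine in place of the fluoro on the aromatic ring would give a step beyond the scatter. They also leave open how a longer chain carrying the sulfanyl group would read on the core of compound 3.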